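This account rests on a few compounds, and the source may have more. Where it says the series, first, only, none or still open, it means among the compounds named here.

Measured in an ADME assay on NCI-H630 cells (Homo sapiens) for cytotoxicity, read by MTT assay, with a stated time of 72 h; a higher number here means that more compound is tolerated, a lower number that less compound is tolerated:
- compound 1 `O=C(O)c1ccc(OCc2ccc(F)cc2)cc1O`: > 40000 nM, a limit of the assay and not a number
- compound 2 `O=C(NCc1ccc(F)cc1)c1cc(S(=O)(=O)N2CCCCC2)cc(O)c1O`: 13000 nM
- compound 3 `O=C(NCc1ccc(C(F)(F)F)cc1)c1cc(S(=O)(=O)N2CCCCC2)cc(O)c1O`: 31000 nM

Compound 3 gives the highest of the two numbers; the nearest is compound 2, the step of a 2.4-fold higher number from compound 2 to compound 3 (0.38 log units; beyond the scatter) being beyond the scatter, while compound 1 sits at the limit of > 40000 nM in this assay, at which 1 of the 3 values shown sits.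

The next compound is compound 4 `O=C(NCc1cccs1)c1cc(S(=O)(=O)N2CCCCC2)cc(O)c1O`; the change is thiophen-2-yl in place of 4-(trifluoromethyl)phenyl on a saturated chain carbon bound to an amide-type nitrogen. Going by the values given here, only the step of a 2.4-fold higher number from compound 2 to compound 3 (0.38 log units; beyond the scatter) touches the same group on the same chain carbon, and it was modest; no measured pair exchanges a six-membered ring for a five-membered one. In this assay the step of a 1.6-fold lower number from compound 3 to compound 4 (0.19 log units; within the scatter) is therefore expected to be small, likely back toward compound 2. Compound 4 is estimated at 20000 nM, range 8000 nM to 50000 nM.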

Compound 4, half-maximal cytotoxic concentration: > 40000 nM
Compound 4: no number, only a limit (the forecaster's own chance of this, stated with the estimate: 25%); at least 2.0-fold (0.30 log units) between middle value and limit.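

In this assay compound 4 gives a limit of the assay and not a number: the limit of > 40000 nM in this assay, at which 2 of the 4 values shown sit.

At this chain carbon, a five-membered aromatic ring with one hetero atom can replace the six-membered carbon rings without lowering the number. The replacement gives an at least 3.0-fold higher number from compound 2 to compound 4 (0.48 log units; beyond the scatter) against the fluorinated ring, whereas an at least 1.2-fold higher number from compound 3 to compound 4 (0.11 log units; that floor lies within the scatter) leaves the order of these two compounds unresolved.

As far as these compounds go, the true size of both steps remains open while compound 4 sits at the limit. Also open, from the compounds shown here alone, is whether furan-2-yl or a simple amine at this place would behave the same way.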